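From Sulfonyl to Carbamoyl on Compound 3

The compounds below may be only part of what the source reports. "The series", "measured", "known", "first", "only" and "open" are said of these compounds alone.

In a functional assay on MDA-MB-436 cells (Homo sapiens) for antiproliferative activity, read by MTT assay, with a stated time of 48 h (on this read-out higher numbers stand for weaker inhibition and lower numbers for stronger inhibition), compound 1 `C=CS(=O)(=O)N1CCN(c2ncnc3sc(-c4cccc5ccccc45)cc23)CC1` gives 28100 nM and compound 2 `C=CS(=O)(=O)N1CCN(c2ncnc3sc(-c4cnn(Cc5ccccc5)c4)cc23)CC1` gives 18300 nM. Compound 3 `CN1CCN(c2ccc(-c3cc4c(N5CCN(S(=O)(=O)/C=C/c6ccccc6)CC5)ncnc4s3)cc2)CC1` has the lowest number of the three at 8670 nM, clearly lower than either of the others. Compound 4 `CN1CCN(c2ccc(-c3cc4c(N5CCN(C(=O)Nc6ccc(C#N)cc6)CC5)ncnc4s3)cc2)CC1` differs from compound 3 in one place: (4-cyanophenyl)carbamoyl in place of (2-phenylethenyl)sulfonyl on an amine nitrogen in a ring. It carries (4-cyanophenyl)carbamoyl in place of (2-phenylethenyl)sulfonyl on an amine nitrogen in a ring. Among the measured compounds shown here, no measured pair shows this change, so its size remains uncertain. Only a small shift toward stronger inhibition, within the usual scatter, is expected, and the estimated step is a 1.4-fold lower number from compound 3 to compound 4 (0.16 log units; within the scatter). For compound 4 the estimated value is 6000 nM, with an expected range from 1500 nM to 24000 nM.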

Compound 4, half-maximal inhibitory concentration: 5010 nM
For compound 4 the middle estimate is 1.2-fold (0.08 log units) above the measured one, and the stated range covers the measured number.
By their numbers in this assay, from the lowest: compounds 4 and 3 (each within the scatter of the next); then compounds 2 and 1 (each within the scatter of the next).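

In this assay the (4-cyanophenyl)carbamoyl group on the ring nitrogen takes the place of (2-phenylethenyl)sulfonyl with a 1.7-fold lower number from compound 3 to compound 4 (0.24 log units; within the scatter) as the step. At this position, then, a sulfonyl is not required to keep the read-out in this range, and the entering group adds a hydrogen-bond donor and a nitrile. No available evidence explains this result. 

As far as these compounds go, the linking group and its aryl part change together here, so their separate contributions remain open. Also open, from the compounds shown here alone, is how a simple acetyl or a plain phenylcarbamoyl would read at this nitrogen.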